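The source may report more compounds than this note shows. Statements on the series, on what has been measured and on what is new or still open speak of the compounds shown alone.

Measured in a functional assay on A549 cells (Homo sapiens) for antiproliferative activity, read by MTT assay, with a stated time of 72 h; on this read-out higher numbers stand for weaker inhibition and lower numbers for stronger inhibition:
- Compound 1 `COc1cc2ncnc(Nc3ccc(F)c(Br)c3)c2cc1OCCCN1CCNCCNCC1`: 34300 nM
- Compound 2 `COc1cc2ncnc(Nc3cccc(C(F)(F)F)c3)c2cc1OCCCN1CCNCCNCC1`: 37300 nM
- Compound 3 `COc1cccc(Nc2ncnc3cc(OC)c(OCCCN4CCNCCNCC4)cc23)c1`: > 50000 nM, a limit and not a number

Compound 3 stands at the limit of > 50000 nM in this assay, at which 1 of the 3 values shown sits. Compound 4 `COc1cc2ncnc(Nc3cccc(I)c3)c2cc1OCCCN1CCNCCNCC1` carries iodo in place of methoxy on an aromatic carbon, meta to a large group: iodo in place of methoxy on an aromatic carbon.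

Among the compounds with values here, three measured steps bear on this. Methoxy arrives in an at least 1.3-fold higher number from compound 2 to compound 3 (0.12 log units; that floor lies within the scatter), and the aryl change gives an at least 1.4-fold higher number from compound 1 to compound 3 (0.16 log units; that floor lies within the scatter). Exchange of the other two aryl groups gives a 1.1-fold higher number from compound 1 to compound 2 (0.04 log units; within the scatter). No large effect is therefore expected. Expected here is an at least 1.3-fold lower number from compound 3 to compound 4 (0.14 log units; that floor lies within the scatter), a small step towards lower numbers at most. For compound 4 the estimated value is 36000 nM, with an expected range of 18000 nM to 65000 nM.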

Compound 4, half-maximal inhibitory concentration: 26200 nM
Beside the measured number, compound 4's estimate is 1.4-fold (0.14 log units) above it, within the range that was stated.
By their numbers in this assay, from the lowest: compounds 4, 1 and 2 (each within the scatter of the next). At a limit, above all of these: compound 3.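

Iodo on an aromatic carbon, meta to a large group, gives an at least 1.9-fold lower number from compound 3 to compound 4 (0.28 log units; that floor lies within the scatter) in this assay, so a measured number is obtained with iodo, but this floor does not separate it from methoxy. Against the other two aryl groups, the change gives a 1.4-fold lower number from compound 2 to compound 4 (0.15 log units; within the scatter) and a 1.3-fold lower number from compound 1 to compound 4 (0.12 log units; within the scatter), so iodo adds no separation from trifluoromethyl or 3-bromo-4-fluorophenyl. Compound 3 remains at a limit and not a number: the limit of > 50000 nM in this assay, at which 1 of the 4 values shown sits.

Still open, on these data alone, is how an amine or a carboxylic acid at this place would read, and whether a longer chain in place of the present one would shift the series.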